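Adding a Methoxy Group Twice: One Step, Two Scaffolds

The source may hold more compounds than are shown below. What is called first, only, known or untested is meant among the compounds shown, and "the series" means these compounds.

Compound 1, `COc1ccc(/C=C/C(=O)c2ccccc2-c2ccc(OC)c(OC)c2)cc1`, gives 1600 nM in a functional assay on A549 cells (Homo sapiens) for antiproliferative activity, read by sulforhodamine B assay, with a stated time of 48 h; a higher number here means a weaker inhibitor, a lower number a stronger inhibitor.
Compound 2, `COc1ccc(/C=C/C(=O)c2ccccc2-c2ccc(OC)c(OC)c2)cc1OC`, gives 8500 nM in this assay.
Compound 3, `COc1ccc(/C=C/C(=O)c2ccccc2-c2cccc(F)c2)cc1`, gives 280 nM in this assay.

The three measured compounds share a chalcone-like arrangement, and compound 3 has the lowest number of the three in this assay. Compound 1 and compound 3 carry different groups on one ring; the difference between the two cores is not broken down here.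

Compound 1 and compound 2 differ in a single place: methoxy in place of hydrogen on an aromatic carbon. This change produced a 5.3-fold higher number from compound 1 to compound 2 (0.73 log units; beyond the scatter) in this assay, a weakening of the inhibition that lies outside the usual spread of repeated measurements.

Compound 4, `COc1ccc(/C=C/C(=O)c2ccccc2-c2cccc(F)c2)cc1OC`, has not yet been measured. It stands to compound 3 exactly as compound 2 stands to compound 1, the difference being (methoxy in place of hydrogen on an aromatic carbon). The surroundings of the change are the same in both pairs, so this is the same change made on a second core.

Among the measured compounds shown here, with only one earlier example of this change, the expectation for compound 4 rests on the step from compound 1 to compound 2 and assumes the two cores respond alike. In this assay compound 4 is therefore expected to show a 5.4-fold higher number from compound 3 to compound 4 (0.73 log units; beyond the scatter), giving an estimated value of 1500 nM, most plausibly between 600 nM and 3800 nM.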

Compound 4, half-maximal inhibitory concentration: 330 nM
Beside the measured number, compound 4's estimate is 4.5-fold (0.66 log units) above it; the measured number lies below the stated range.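

In this assay, the methoxy group that weakened inhibition on the first core has no readable effect on the core carrying 3-fluorophenyl, where the same change gives a 1.2-fold higher number from compound 3 to compound 4 (0.07 log units; within the scatter). The two steps do not match, so in this series the cost of this methoxy group cannot simply be carried from one core to the other: the same change on two cores in this assay, a 5.3-fold higher number (0.73 log units; beyond the scatter) from compound 1 to compound 2 and a 1.2-fold higher number (0.07 log units; within the scatter) from compound 3 to compound 4, 4.5-fold (0.65 log units) apart, beyond the scatter of two such steps The remaining step, a 26-fold lower number from compound 2 to compound 4 (1.41 log units; beyond the scatter), shows that with the added methoxy group in place, 3-fluorophenyl in place of 3,4-dimethoxyphenyl makes a large difference, but these pairs do not show why the two cores respond differently, nor how a further core would respond.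

The compounds shown leave open whether a hydroxyl group, an ethoxy group or an amine, placed ortho to a methoxy group on the same ring, would also differ between the two cores. Among the compounds shown here, they also leave open which part of the 3,4-dimethoxyphenyl group matters for the difference between the cores, since a ring carrying only one methoxy group, or a phenyl ring with no substituent, does not appear among them.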